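The source may hold more compounds than are shown below. What is called first, only, known or untested is meant among the compounds shown, and "the series" means these compounds.

Compound 1 `Nc1ncnc2c1nc(-c1ccco1)n2CCCO`: 60 nM
Compound 2 `Cn1c(-c2ccco2)nc2c(NC(=O)Nc3ccccc3)ncnc21`: 496 nM

Of the compounds shown here, two have been measured in an assay on CHO cells for displacement of a labelled ligand from adenosine receptor A1 (Homo sapiens); a lower number here means a stronger inhibitor, a higher number a weaker inhibitor. Compound 1 gives 60 nM, the lower of the two numbers, so it is the stronger inhibitor of the pair. Compound 2 gives 496 nM, a number beyond the scatter above that of compound 1; since compound 2 differs from compound 1 in more than one place, no single change can be read from this gap.

Compound 3 `Cn1c(-c2ccco2)nc2c(N)ncnc21` is not yet measured. It differs from compound 1 in one place: hydrogen in place of 2-hydroxyethyl on a saturated chain carbon bound to an aromatic nitrogen. For the measured compounds named here, no measured pair shows what this change does on its own. The change removes the hydroxyl-bearing part of the chain while keeping the shared core intact, so a small step toward a higher number is expected, within or only slightly beyond the scatter. For compound 3 a value of 150 nM is estimated, in the range 40 nM to 600 nM, which would mean a step of a 2.5-fold higher number from compound 1 to compound 3 (0.40 log units; beyond the scatter).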

Compound 3, inhibition constant: 62 nM
The estimate for compound 3 lay 2.4-fold (0.38 log units) above the measured number; measured number inside the range.
By their numbers in this assay, from the lowest: compounds 1 and 3 (each within the scatter of the next); then compound 2.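

Replacing 2-hydroxyethyl with hydrogen on a saturated chain carbon bound to an aromatic nitrogen, which shortens 3-hydroxypropyl to methyl, gives a step of a 1.0-fold higher number from compound 1 to compound 3 (0.01 log units; within the scatter) in this assay. This first single-place comparison shows that, on this core, the numbers with the two chains cannot be told apart, so the 3 heavy atoms of 2-hydroxyethyl, including its oxygen, are not needed to keep the number in this range. No measurement shown here explains this result.

From the compounds shown here alone, it remains open whether the same place tolerates other groups, such as an amine or a carboxylic acid at the chain end, or a longer chain. One pair also cannot show whether this replacement would read the same way on a different core.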